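Unmasking a methoxy: compound 3 to compound 4

The source may hold more compounds than are shown below. What is called first, only, known or untested is meant among the compounds shown, and "the series" means these compounds.

Measured so far:
- compound 1, `COc1cc(C)cc(-c2c(-c3ccnc(-c4ccc(C(C)=O)cc4)c3)cnn2CC#N)c1`: 34%
- compound 2, `Cc1cc(O)cc(-c2nn(CC#N)cc2-c2ccnc(-c3ccc(Oc4ccccc4)cc3)c2)c1`: 6%
- compound 3, `COc1cc(C)cc(-c2nn(CC#N)cc2-c2ccnc(-c3ccc(N(C)C)cc3)c2)c1`: 3%

Of the compounds shown here, three have been tested in a functional assay on NCI-H226 cells (Homo sapiens) for cytotoxicity, read by sulforhodamine B assay, with a stated time of 48 h, tested at 1 uM; on this read-out higher numbers stand for a weaker effect at the one concentration tested and lower numbers for a stronger effect. Compound 3 gives the lowest of the three numbers, 3%. Compound 2 sits closest to it with 6%, a difference that lies within the usual scatter, so the two cannot be told apart. Compound 1 stands furthest away with 34%, a gap that is beyond the scatter, so compound 1 clearly acts less strongly at this concentration than compound 3.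

The next compound is compound 4, `Cc1cc(O)cc(-c2nn(CC#N)cc2-c2ccnc(-c3ccc(N(C)C)cc3)c2)c1`, which has not yet been measured. It differs from compound 3 in a single place: hydrogen in place of methyl on an oxygen on an aromatic ring. Among the measured compounds shown here, no step between two measured compounds isolates this exact change, so the direction of the step in this assay is open. The change is small in size, and the values of compound 2 and compound 3 show that this region tolerates variation without a visible shift. Compound 4 is therefore expected to behave much like compound 3, with an estimated step of a number 3 percentage points higher from compound 3 to compound 4 (within the scatter), no larger than the scatter. Compound 4 is expected to give about 6%, within a range of 0% to 20%.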

Compound 4, a percentage reported as activity, at one concentration (the size of the read-out at that concentration, not a potency): 19%
Beside the measured number, compound 4's estimate is 13 percentage points below it; the measured number falls inside the stated range.
By their numbers in this assay, from the lowest: compounds 3 and 2 (each within the scatter of the next); then compound 4; then compound 1.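

Within this assay, the step that removes the methyl from the oxygen on the aromatic ring, turning 3-methoxy-5-methylphenyl into 3-hydroxy-5-methylphenyl, is a number 16 percentage points higher from compound 3 to compound 4 (beyond the scatter) and shows that this small change weakens the effect at the one concentration tested. Among the compounds shown here, the other new step, with dimethylamino in place of phenoxy on an aromatic carbon, is a number 13 percentage points higher from compound 2 to compound 4 (beyond the scatter) and shows that, with the hydroxy group in place, the group at that second site also affects the read-out, something the earlier compounds could not show because no two of them differed in one place. No measurement at hand offers an explanation for either step.

Still open, on these data alone, is whether the methoxy group is the best choice for that oxygen or merely better than hydroxy, a question that an ethoxy group, or an amine in place of the hydroxy, could help to answer. As far as these compounds go, it is also open whether the change from methoxy to hydroxy would have a similar size in a compound carrying phenoxy rather than dimethylamino.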